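This account rests on a few compounds, and the source may have more. Where it says the series, first, only, none or still open, it means among the compounds named here.

Three measured compounds share one core and differ only in the group on a carbonyl carbon whose other neighbour is an amide-type nitrogen. Compound 1 `COc1ccc(/C(=C(/CCNC(=O)NCc2ccccc2)c2ccccc2)c2ccccc2)cc1` carries benzylamino there. In a functional assay on MDA-MB-231 cells (Homo sapiens) for cytotoxicity, read by MTT assay, with a stated time of 72 h (a higher number here means a weaker inhibitor, a lower number a stronger inhibitor), compound 1 reaches only the limit of the assay, > 50000 nM. Compound 2 `COc1ccc(/C(=C(/CCNC(=O)N2CCCCC2)c2ccccc2)c2ccccc2)cc1` has piperidin-1-yl in the same place, and in this assay compound 2 likewise gives only a limit, > 50000 nM. Compound 3 `COc1ccc(/C(=C(/CCNC(=O)N2CCCC2)c2ccccc2)c2ccccc2)cc1` carries pyrrolidin-1-yl, and in this assay compound 3 again gives only a limit, > 50000 nM. Compound 3 therefore stands where all three stand, at the limit of > 50000 nM in this assay, at which 3 of the 3 values shown sit, and the steps among them cannot be read: a step that the two limits leave unreadable from compound 1 to compound 2, a step that the two limits leave unreadable from compound 1 to compound 3 and a step that the two limits leave unreadable from compound 2 to compound 3.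

Compound 4 `COc1ccc(/C(=C(/CCNC(=O)C(=O)N2CCCC2)c2ccccc2)c2ccccc2)cc1` is the compound yet to be measured. It differs from compound 3 by (pyrrolidin-1-yl)carbonyl in place of pyrrolidin-1-yl on a carbonyl carbon, so a second carbonyl now links the ring to the amide-type nitrogen. For the measured compounds named here, none of the measured steps covers such a change, and the three bear on it only by showing that alterations at this carbonyl carbon have not moved any value off the limit. The expectation for compound 4 in this assay is therefore a step of a number no higher from compound 3 to compound 4 (the limit leaves the size open), which is to say none that can be read. Compound 4 is estimated at 50000 nM, within 20000 nM to 200000 nM, with a limit the most likely outcome.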

Compound 4, half-maximal inhibitory concentration: 48600 nM
Beside the measured number, compound 4's estimate is 1.0-fold (0.01 log units) above it, and the stated range covers the measured number.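

In this assay, for the compounds shown here, compound 4 is the only one of the four compounds to give a number rather than a limit, 48600 nM, so a second carbonyl at this position is the one change here that yields a readable value. Set against the limits of the other compounds, that value gives an at least 1.0-fold lower number from compound 3 to compound 4 (0.01 log units; that floor lies within the scatter), an at least 1.0-fold lower number from compound 2 to compound 4 (0.01 log units; that floor lies within the scatter) and an at least 1.0-fold lower number from compound 1 to compound 4 (0.01 log units; that floor lies within the scatter), and each of these is only a floor, so the true size of the change stays unknown and may be very small. Cytotoxicity at this position therefore remains weak in every compound shown, and the value of compound 4 sits right at the edge of what the other three reached, with the steps among those three unreadable: the limit of > 50000 nM in this assay, at which 3 of the 4 values shown sit.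

Whether the second carbonyl can carry the number much lower remains open, since only one group, pyrrolidin-1-yl, is shown on it. A morpholin-4-yl ring, a dimethylamino group or a carboxylic acid in that place would show whether the second carbonyl alone accounts for a readable value or whether the group attached to it matters as well.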